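Working notes: the step from compound 2 to compound 4

A few compounds are considered here, and "the series" means these few. Any claim that something is new, unique, unknown or untested is made for them only; others in the source may bear on it.

Three compounds sharing the core of compound 1 (`Cc1cc(NC(=O)Nc2cccc(F)c2)c2ccccc2n1`) have been run so far in an ADME assay on HEK293 cells (Homo sapiens) for cytotoxicity, with a stated time of 72 h; a lower number here means that less compound is needed, a higher number that more compound is needed for the effect. Compound 1 gives > 25000 nM, which is a limit of the assay and not a number. Compound 3 (`Cc1cc(NC(=O)Nc2ccccc2C(F)(F)F)c2ccccc2n1`) gives > 25000 nM, again a limit and not a number. For the measured compounds named here, compound 2 (`COC(=O)c1ccc(NC(=O)Nc2cc(C)nc3ccccc23)cc1`) gives 15000 nM, the only actual number in the set. The other two results are limits, so no firm order among the three is drawn.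

Compound 4 (`Cc1cc(NC(=O)Nc2ccc(N)cc2)c2ccccc2n1`) has not yet been measured in this assay. It carries amino in place of methoxycarbonyl on an aromatic carbon, para to a large group: amino in place of methoxycarbonyl on an aromatic carbon. Going by the values given here, no measured pair shows a change in one place, so nothing yet gauges this exchange directly. Among the compounds with values here, with compound 2 at 15000 nM as the only number to start from, no step beyond the scatter is expected. The estimated step is a 1.2-fold higher number from compound 2 to compound 4 (0.08 log units; within the scatter), which is expected to stay within the usual scatter. A result reported only as a limit would also fit the set so far. For compound 4 the expected value is 18000 nM, with an estimated range of 7000 nM to 35000 nM.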

Compound 4, half-maximal effective concentration: > 25000 nM
Compound 4 gave a limit, no number; the forecaster's own chance of this, stated with the estimate: 40%; middle value at least 1.3-fold (0.14 log units) away from the limit.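

In this assay, for the compounds shown here, this is the first comparison that differs in one place: amino in place of methoxycarbonyl on an aromatic carbon, para to a large group, gives an at least 1.6-fold higher number from compound 2 to compound 4 (0.22 log units; that floor lies within the scatter). Compound 4 gives > 25000 nM, which is a limit of the assay and not a number. The step is therefore only a floor, the step that involves two limits cannot be read, and compound 2 remains the only compound in the set with an actual number: the limit of > 25000 nM in this assay, at which 3 of the 4 values shown sit.

From the compounds shown here alone, it remains open how far the true step from methoxycarbonyl to amino extends, and whether it passes the usual scatter at all. Also open, going by these compounds, is whether a carboxylic acid or an acetyl group on the same aromatic carbon would give an actual number in this assay, which would show whether the number for compound 2 depends on methoxycarbonyl itself or is shared by other groups at this position.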